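The source may report more compounds than this note shows. Statements on the series, on what has been measured and on what is new or still open speak of the compounds shown alone.

Three compounds built on a shared core have been examined in an ADME assay on Vero cells (Chlorocebus sabaeus) for cytotoxicity, read by CCK-8 assay, with a stated time of 72 h; on this read-out higher numbers stand for weaker inhibition and lower numbers for stronger inhibition. Compound 1 `Cc1nn2cccc(C)c2c1C(=O)NCc1ccc(N2CCC(c3ccc(OC(F)(F)F)cc3)CC2)cc1` has "not determined" (no result reported). For compound 2 `Cc1ccc2c(C(=O)NCc3ccc(N4CCC(c5ccc(OC(F)(F)F)cc5)CC4)cc3)c(C)nn2c1` the read-out reports only a limit, > 100000 nM. For compound 3 `CCc1ccn2nc(C)c(C(=O)NCc3ccc(N4CCC(c5ccc(OC(F)(F)F)cc5)CC4)cc3)c2c1` the read-out likewise reports only a limit, > 100000 nM. The step from compound 2 to compound 3 is thus a step that the two limits leave unreadable from compound 2 to compound 3; the single fixed point is the limit of > 100000 nM in this assay, at which 2 of the 3 values shown sit. Compound 4 `CCc1nn2ccc(Cl)cc2c1C(=O)NCc1ccc(N2CCC(c3ccc(OC(F)(F)F)cc3)CC2)cc1` differs from compound 3 by a group of 12 heavy atoms (9 carbon, 2 nitrogen, 1 chlorine; one five-membered aromatic ring with 2 hetero atoms, one six-membered aromatic ring with 1 hetero atom) in place of a group of 12 heavy atoms (10 carbon, 2 nitrogen; one five-membered aromatic ring with 2 hetero atoms, one six-membered aromatic ring with 1 hetero atom), on a carbonyl carbon. Among the measured compounds shown here, no measured step speaks to this change, and the two limits show no direction, so the expected step from compound 3 to compound 4 in this assay, a number no higher from compound 3 to compound 4 (the limit leaves the size open), is none beyond the scatter. Compound 4 is accordingly expected to give about 100000 nM, within a range from 40000 nM to 300000 nM.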

Compound 4, half-maximal inhibitory concentration: > 100000 nM
Compound 4 gave a limit, no number (the forecaster's own chance of this, stated with the estimate: 80%); the middle value lies on the limit itself.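

Compound 2, compound 3 and compound 4 each give a limit of the assay rather than a number, so no step among them can be read: the limit of > 100000 nM in this assay, at which 3 of the 4 values shown sit.

From the compounds shown here alone, whether changing the group on the carbonyl carbon shifts the result at all in this assay remains open.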